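Trading a ketone aryl group for a benzylamide

This account rests on a few compounds, and the source may have more. Where it says the series, first, only, none or still open, it means among the compounds named here.

Compound 1 `COc1cc(-c2nnc(SCC(=O)c3cccc(Br)c3)n2N)cc(OC)c1OC` and compound 2 `COc1ccc(C(=O)CSc2nnc(-c3cc(OC)c(OC)c(OC)c3)n2N)cc1` share one core and differ only in the aryl group attached to the carbonyl carbon. In a functional assay on HCT-116 cells (Homo sapiens) for antiproliferative activity, read by MTT assay, with a stated time of 48 h (on this read-out lower numbers stand for stronger inhibition and higher numbers for weaker inhibition), compound 1 gives 5320 nM, while compound 2 gives 1240 nM; the change of 4-methoxyphenyl in place of 3-bromophenyl gives a 4.3-fold lower number from compound 1 to compound 2 (0.63 log units; beyond the scatter). Compound 2 thus has the lower of the two numbers.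

Compound 3 `COc1cc(-c2nnc(SCC(=O)NCc3ccc(Cl)cc3)n2N)cc(OC)c1OC` alters the same position: (4-chlorobenzyl)amino in place of 4-methoxyphenyl on a carbonyl carbon. Among the measured compounds shown here, the only measured step swaps one aryl group for another on that carbonyl carbon and was modest; it does not test a change from an aryl ketone to an amide bearing a benzyl group, so no measured step bears directly on this change. Compound 3 is therefore expected to stay near compound 2, with a wide range and a mild lean toward a higher number, which means an expected step of a 2.0-fold higher number from compound 2 to compound 3 (0.30 log units; within the scatter). The estimate for compound 3 is 2500 nM, between 600 nM and 10000 nM.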

Compound 3, half-maximal inhibitory concentration: > 100000 nM
Compound 3 was reported as a limit; the forecaster's own chance of this, stated with the estimate: 10%; middle value at least 40-fold (1.60 log units) away from the limit.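

Compound 3 is reported only as a limit, not as a number: the limit of > 100000 nM in this assay, at which 1 of the 3 values shown sits. Swapping one aryl group for another on the carbonyl carbon gave only a 4.3-fold lower number from compound 1 to compound 2 (0.63 log units; beyond the scatter), whereas moving from an aryl ketone to an amide gives an at least 80-fold higher number from compound 2 to compound 3 (1.90 log units; beyond the scatter) and an at least 18-fold higher number from compound 1 to compound 3 (1.27 log units; beyond the scatter). This position therefore accepts a change of aryl group with a modest shift, but activity is largely lost with the (4-chlorobenzyl)amino group, whichever of the two ketones serves as the reference.

From the compounds shown here alone, it remains open which part of that group matters: the amide hydrogen, the benzyl carbon or the chlorine, which all arrive together in compound 3. An unsubstituted benzyl amide, or an amide with a methyl group in place of the amide hydrogen, could begin to separate these parts.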